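Replacing the Difluorophenyl Ring with an Aminophenyl Ring

The source may report more compounds than this note shows. Statements on the series, on what has been measured and on what is new or still open speak of the compounds shown alone.

Measured compounds:
compound 1 `COc1ccc(C(=O)c2cc(OC)c(OC)c(OC)c2)cc1NC(=O)/C=C/c1cccc(OC(F)(F)F)c1` — 9200 nM
compound 2 `COc1ccc(C(=O)c2cc(OC)c(OC)c(OC)c2)cc1NC(=O)/C=C/c1ccc(F)c(F)c1` — 8900 nM

In a functional assay on ME-180 cells (Homo sapiens) for cytotoxicity, read by MTT assay, with a stated time of 72 h (on this read-out higher numbers stand for weaker inhibition and lower numbers for stronger inhibition), compound 1 gives 9200 nM and compound 2 gives 8900 nM. Compound 2 holds the lower of the two numbers, but the step of a 1.0-fold lower number from compound 1 to compound 2 (0.01 log units; within the scatter) lies within the scatter, so the two compounds cannot be told apart on these data. Compound 3 `COc1ccc(C(=O)c2cc(OC)c(OC)c(OC)c2)cc1NC(=O)/C=C/c1ccc(N)cc1` differs from compound 2 by 4-aminophenyl in place of 3,4-difluorophenyl on a double-bonded chain carbon bound to a double-bonded chain carbon. Among the measured compounds shown here, the only measured step bears on this change loosely: it exchanged one substituted phenyl ring for another at the same place and left the number essentially where it was, as a 1.0-fold lower number from compound 1 to compound 2 (0.01 log units; within the scatter) shows. For the measured compounds named here, no measured compound carries an amino group on that ring, so the data give no direct guide to its effect. The expectation is therefore no step beyond the scatter, with a wide band of uncertainty around it. Compound 3 is expected to give 9000 nM, within a range of 3000 nM to 30000 nM. This estimate for compound 3 corresponds to an expected step of a 1.0-fold higher number from compound 2 to compound 3 (0.00 log units; within the scatter), which is expected to stay within the scatter.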

Compound 3, half-maximal inhibitory concentration: 16000 nM
The estimate for compound 3 lay 1.8-fold (0.25 log units) below the measured number; low and high end bracket the measured number.
By their numbers in this assay, from the lowest: compounds 2, 1 and 3 (each within the scatter of the next).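

With the 4-aminophenyl ring, the first ring at this place to carry an amino group, this assay gives a 1.8-fold higher number from compound 2 to compound 3 (0.25 log units; within the scatter) and so does not separate it from the 3,4-difluorophenyl ring. Set against the 3-(trifluoromethoxy)phenyl ring, the comparison reads the same, with a 1.7-fold higher number from compound 1 to compound 3 (0.24 log units; within the scatter), so this amino-bearing ring and the two fluorine-bearing rings on the double-bonded chain carbon cannot be told apart in this cytotoxicity read-out, and the amino group adds a new kind of substituent at this place without a resolved difference in the number. Nothing among the available data offers an explanation for how these numbers sit relative to one another.

The compounds shown leave open whether any group at this place can move the number beyond the scatter, since all three carry a substituted phenyl ring there. A plain phenyl ring, a carboxylic acid or a dimethylamino group on that ring, or a longer chain between the ring and the amide would each test this place further.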